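Aryl swap on the shared dihydropyran core: compound 2 to 4

The compounds below may be only part of what the source reports. "The series", "measured", "known", "first", "only" and "open" are said of these compounds alone.

Three compounds of the series carry the same core and differ only in the aryl group on the saturated ring carbon. Compound 1 `N#CC1=C(N)OC(c2c[nH]c3ccccc23)=C(C#N)C1c1ccccc1` gives 19.3% in a functional assay, tested at 100 ug/mL; a lower number here means a weaker effect, a higher number a stronger effect of the compound at the concentration tested. Compound 2 `N#CC1=C(N)OC(c2c[nH]c3ccccc23)=C(C#N)C1c1ccccc1Cl` gives 10.4% in this assay, the lowest of the three numbers, although the step of a number 8.9 percentage points lower from compound 1 to compound 2 (within the scatter) is within the scatter; only compound 3 `COc1cc(Br)c(C2C(C#N)=C(N)OC(c3c[nH]c4ccccc34)=C2C#N)cc1OC`, with 20.5% in this assay, lies beyond the scatter above it.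

Compound 4 `COc1ccc(C2C(C#N)=C(N)OC(c3c[nH]c4ccccc34)=C2C#N)cc1OC` has not yet been measured. The change from compound 2 is 3,4-dimethoxyphenyl in place of 2-chlorophenyl on a saturated ring carbon. Among the compounds with values here, no measured step describes this exact exchange; the one measured step, a number 8.9 percentage points lower from compound 1 to compound 2 (within the scatter), shows only that adding chlorine to the phenyl ring did not move the number beyond the scatter. Compound 1 and compound 3, which lack a chlorine, sit close to each other in this assay.

The expectation is therefore a modest rise, a number 8.6 percentage points higher from compound 2 to compound 4 (within the scatter), not safely beyond the scatter. Compound 4 is estimated at 19% in this assay, within 9% to 29%.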

Compound 4, a percentage reported as activity, at one concentration (the size of the read-out at that concentration, not a potency): 19.1%
Compound 4: the middle estimate sits 0.1 percentage points below what was measured; the measured number falls inside the stated range.
By their numbers in this assay, from the lowest: compounds 2, 4, 1 and 3 (each within the scatter of the next, the first and the last beyond it).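

At the saturated ring carbon, 3,4-dimethoxyphenyl in place of 2-chlorophenyl gives a number 8.7 percentage points higher from compound 2 to compound 4 (within the scatter) in this assay and so does not separate the two aryl groups, while 3,4-dimethoxyphenyl in place of phenyl gives a number 0.2 percentage points lower from compound 1 to compound 4 (within the scatter) and hydrogen in place of bromo on the aromatic ring gives a number 1.4 percentage points lower from compound 3 to compound 4 (within the scatter) in the same read-out. Within the data shown here, compound 4 therefore cannot be told apart from any of the other three, and compound 2 and compound 3 remain the only pair beyond the scatter. No measured evidence explains these numbers.

Open, on these data alone, is whether an aminophenyl or carboxyphenyl group, or a butyl chain, at this carbon would move the read-out beyond the scatter from compound 1. As far as these compounds go, all four compounds keep the 1H-indol-3-yl group, so that position remains untested here.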